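Phenyl for pyridinyl: an expected lipophilicity step

The source may hold more compounds than are shown below. What is called first, only, known or untested is meant among the compounds shown, and "the series" means these compounds.

Compounds measured so far:
compound 1, `CCNC(=O)Nc1cc(-c2nc(C(C)(C)C)cs2)c(-c2cncc(C(=O)O)c2)cn1`, 0.12
compound 2, `CCNC(=O)Nc1cc(-c2ccncc2)c(-c2cncc(C(=O)O)c2)cn1`, -0.82

In a physicochemical assay for lipophilicity, using the shake flask method, in phosphate buffer, measured as octanol-water partition, with a stated time of 1 h, at pH 7.4 (a higher number here means a more lipophilic compound, a lower number a more polar compound), compound 2 stands lowest of the two numbers; its nearest neighbour is compound 1, which sits a number 0.94 log units lower from compound 1 to compound 2 (beyond the scatter). That single step, from a 4-(tert-butyl)-1,3-thiazol-2-yl group to a pyridin-4-yl group on the shared core, is the only one that bears on what follows, and it lies beyond the scatter.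

Compound 3, `CCNC(=O)Nc1cc(-c2ccccc2)c(-c2cncc(C(=O)O)c2)cn1`, has not yet been measured in this assay. It differs from compound 2 in one place: phenyl in place of pyridin-4-yl on an aromatic carbon. The change runs the other way from the measured step, removing the one hydrogen-bond acceptor of the pyridin-4-yl group and leaving a carbon-only ring of the same size. Since compound 1 carries a larger, carbon-rich group and gives 0.12, compound 3 is expected to move upward by a number 1.12 log units higher from compound 2 to compound 3 (beyond the scatter), landing in the region of compound 1 rather than below it. The estimate for compound 3 in this assay is 0.3, with a range from -0.2 to 0.8.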

Compound 3, distribution coefficient: -0.31
Beside the measured number, compound 3's estimate is 0.61 log units above it, and the stated range ends above it.
By their numbers in this assay, from the lowest: compound 2; then compound 3; then compound 1.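

In this assay, putting phenyl in place of pyridin-4-yl on the aromatic carbon opposite the ring nitrogen gives a number 0.51 log units higher from compound 2 to compound 3 (beyond the scatter) and so shows that exchanging one ring nitrogen for carbon, with the ring size unchanged, moves the number beyond the scatter at this position. Phenyl does not reach the level of the 4-(tert-butyl)-1,3-thiazol-2-yl group, since the change gives a number 0.43 log units lower from compound 1 to compound 3 (beyond the scatter) and places phenyl between the two groups seen earlier, so that the three compounds run from compound 2 through compound 3 to compound 1, with every step between them beyond the scatter. Nothing available here accounts for the size of either step.

The compounds shown leave open whether the nitrogen must sit where it does in pyridin-4-yl, which pyridin-3-yl or pyridin-2-yl at the same position would test. They also do not separate the contribution of the tert-butyl group from that of the thiazole ring it sits on, a question that an unsubstituted 1,3-thiazol-2-yl group or a 4-tert-butylphenyl group at this position would address.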